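Bromo for hydrogen on the phenyl of compound 3

A few compounds are considered here, and "the series" means these few. Any claim that something is new, unique, unknown or untested is made for them only; others in the source may bear on it.

Three compounds of the series share one core and differ at the substituent on the triazole nitrogen. Compound 1 `CCc1ccc(NC(=O)Cn2cc(COc3ccc4c(c3)CCC4)nn2)cc1` and compound 2 `O=[N+]([O-])c1cccc(-n2cc(COc3ccc4c(c3)CCC4)nn2)c1` carry an amide-linked ethylphenyl group and a nitrophenyl group; in an ADME assay on HEK293 cells (Homo sapiens) for inhibition, read by MTT assay, with a stated time of 48 h, tested at 25 uM (on this read-out higher numbers stand for more inhibition at the one concentration tested (going by the name of the read-out) and lower numbers for less inhibition), compound 1 gives "not determined" (no result reported) and compound 2 gives "not determined" (no result reported), so for neither was a result obtained. Compound 3 `c1ccc(-n2cc(COc3ccc4c(c3)CCC4)nn2)cc1` carries an unsubstituted phenyl group, and in this assay compound 3 gives 23.4%. For the measured compounds named here, that is the only number the series holds so far, so compound 3 stands alone and no comparison within measured compounds is possible.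

The next entry, compound 4 `Brc1ccccc1-n1cc(COc2ccc3c(c2)CCC3)nn1`, is to be measured in this assay. It differs from compound 3 in one place: bromo in place of hydrogen on an aromatic carbon. Read one bond further out, the change is phenyl to 2-bromophenyl.

Going by the values given here, with no step between measured compounds available, the change is judged only from its small size, one bromine entering and no ring, donor or acceptor added. The step from compound 3 to compound 4 in this assay is expected to be modest and to stay near the scatter of repeated measurements, a number 4.6 percentage points higher from compound 3 to compound 4 (within the scatter), leaning slightly upward if anything. On that basis compound 4 is estimated to give 28%, with a range from 10% to 50%.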

Compound 4, a percentage reported as inhibition, at one concentration (the size of the read-out at that concentration, not a potency): 16.5%
For compound 4 the middle estimate is 11.5 percentage points above the measured one, within the range that was stated.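

In this assay, for the compounds shown here, the change from phenyl to 2-bromophenyl gives a number 6.9 percentage points lower from compound 3 to compound 4 (within the scatter), the first step that can be read between two measured compounds. It shows that one bromine, placed on an aromatic carbon ortho to a large group, with no ring, donor or acceptor added, does not move the read-out beyond the scatter of repeated measurements, so compound 3 and compound 4 cannot be told apart at the one concentration tested. No measured property is available that bears on this result.

Steps involving compound 1 or compound 2 cannot be read, as neither has a reported result, so the amide-linked ethylphenyl and nitrophenyl groups remain uncompared with the unsubstituted phenyl of compound 3. From the compounds shown here alone, whether any other group on the phenyl at this place, such as an amine, a carboxylic acid or a longer alkyl chain, would give a step beyond the scatter remains open, and a single step from compound 3 supports no trend for the series.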